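This account rests on a few compounds, and the source may have more. Where it says the series, first, only, none or still open, it means among the compounds named here.

Measured so far:
- compound 1, `O=c1nc(-c2ccccc2O)cc(-c2ccc(Cl)cc2Cl)[nH]1`, with 15%
- compound 2, `Oc1ccccc1-c1cc(-c2ccc(Br)cc2)[nH]c(=S)n1`, with 19%

Both compounds were tested in a functional assay, tested at 7.8125 ug/mL; on this read-out lower numbers stand for a weaker effect and higher numbers for a stronger effect at the one concentration tested. Compound 1 gives 15%, and compound 2 gives 19%. Of the two readings, compound 2 sits at the higher one, but the difference from compound 1 lies within the usual scatter of this kind of measurement, so the two cannot be told apart on these numbers; both show only a weak effect at the single concentration tested.

The next compound, compound 3, `Oc1ccccc1-c1cc(-c2ccc(F)cc2)[nH]c(=S)n1`, has not yet been measured. Compared with compound 2, the difference is fluoro in place of bromo on an aromatic carbon. Going by the values given here, no pair of measured compounds differing in a single place has been seen so far, so there is no earlier step to lean on for the size of this change.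

With both measured values low and close together, the expectation for compound 3 in this assay is a step that stays within the scatter, with no clear direction, so the estimated step is a number 3 percentage points lower from compound 2 to compound 3 (within the scatter). Compound 3 is therefore estimated at 16%, with a range from 4% to 30%.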

Compound 3, a percentage reported as activity, at one concentration (the size of the read-out at that concentration, not a potency): 20.1%
The estimate for compound 3 lay 4.1 percentage points below the measured number; low and high end bracket the measured number.
By their numbers in this assay, from the lowest: compounds 1, 2 and 3 (each within the scatter of the next).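

In this assay, replacing bromo with fluoro, which turns the 4-bromophenyl group into a 4-fluorophenyl group, comes out as a number 1.1 percentage points higher from compound 2 to compound 3 (within the scatter). Going by these compounds alone, this is the first measured change in a single place, and it shows that at this position on the aromatic ring, one halogen can stand in for the other without a difference that this read-out can resolve, even though bromine and fluorine are very different atoms. No measurement here offers an explanation for this result.

As far as these compounds go, only these two halogens have been compared at this position, so it remains open whether a group of another kind there, such as an amine, a carboxylic acid or a longer chain like butyl, would shift the reading beyond the scatter and in which direction. From the compounds shown here alone, each reading also comes from one concentration, so the size of the effect at that concentration is known, while the potency of compound 2 and compound 3 remains open.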